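From 3-fluorophenyl to 3-chlorophenyl: working notes on compound 4

This account rests on a few compounds, and the source may have more. Where it says the series, first, only, none or still open, it means among the compounds named here.

Measured in an ADME assay on MCF-10A cells (Homo sapiens) for inhibition, with a stated time of 48 h; on this read-out lower numbers stand for stronger inhibition and higher numbers for weaker inhibition:
compound 1 `O=C(Nc1ccc(Cl)cc1)N1CCC[C@H]1c1nc(-c2ccccc2)no1`: > 50000 nM
compound 2 `Cc1cccc(-c2noc([C@@H]3CCCN3C(=O)Nc3ccc(Cl)cc3)n2)c1`: > 50000 nM
compound 3 `O=C(Nc1ccc(Cl)cc1)N1CCC[C@H]1c1nc(-c2cccc(F)c2)no1`: > 50000 nM

Compound 3 stands at > 50000 nM, which is a limit of the assay and not a number. The two other values are limits as well, and the series as a whole shows (the limit of > 50000 nM in this assay, at which 3 of the 3 values shown sit). Compound 3 therefore has no numerical position within the group.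

Compound 4 `O=C(Nc1ccc(Cl)cc1)N1CCC[C@H]1c1nc(-c2cccc(Cl)c2)no1` carries chloro in place of fluoro on an aromatic carbon, with 3-fluorophenyl becoming 3-chlorophenyl: chloro in place of fluoro on an aromatic carbon.

Within the data shown here, three measured steps bear on this change. Among the measured compounds shown here, the first is a step that the two limits leave unreadable from compound 1 to compound 3, the second is a step that the two limits leave unreadable from compound 1 to compound 2, and the third is a step that the two limits leave unreadable from compound 2 to compound 3. None of them provides a size, so no readable size carries over to the new change, and no step beyond the scatter is expected in this assay. The step expected is a number no higher from compound 3 to compound 4 (the limit leaves the size open). A report of compound 4 as a limit again is the most likely outcome. For compound 4 the estimated value is 50000 nM, with an expected range of 25000 nM to 100000 nM.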

Compound 4, half-maximal inhibitory concentration: > 50000 nM
Compound 4 gave a limit, no number; the forecaster's own chance of this, stated with the estimate: 85%; the middle value sits exactly at the limit.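

Compound 4, like compound 1, compound 2 and compound 3, gives a limit and not a number in this assay, so no step among these four compounds can be read: the limit of > 50000 nM in this assay, at which 4 of the 4 values shown sit.

The compounds shown leave open whether any group on this aromatic ring would give a numerical value in this assay, and what size such a step would have.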